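This account rests on a few compounds, and the source may have more. Where it says the series, first, only, none or still open, it means among the compounds named here.

Values in an ADME assay on HeLa Rh cells (Homo sapiens) for cytotoxicity, read by microscopy; on this read-out higher numbers stand for lower toxicity in this test and lower numbers for higher toxicity in this test:
compound 1 `COc1cc(CC(O)c2ccc(-c3ccc(C#N)cc3)cc2)c([N+](=O)[O-])cc1OC`: 4700 nM
compound 2 `COc1cc(CC(O)c2ccc(-c3ccc(C=O)cc3)cc2)c([N+](=O)[O-])cc1OC`: > 245000 nM
compound 3 `COc1cc(CC(O)c2ccc(-c3ccc(CO)cc3)cc2)c([N+](=O)[O-])cc1OC`: > 244000 nM

Compound 3 gives only a limit, > 244000 nM, and no number. Compound 2 also gives only a limit, > 245000 nM. Compound 1 alone gives a number, 4700 nM.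

The next compound, compound 4 `COc1cc(CC(O)c2ccc(-c3ccc(C(F)(F)F)cc3)cc2)c([N+](=O)[O-])cc1OC`, has trifluoromethyl in place of hydroxymethyl on an aromatic carbon.

Going by the values given here, two measured steps bear on this place: an at least 51-fold higher number from compound 1 to compound 3 (1.71 log units; beyond the scatter), and an at least 52-fold higher number from compound 1 to compound 2 (1.71 log units; beyond the scatter). Both are large and beyond the scatter, so this position clearly moves the read-out in this assay. The step that the two limits leave unreadable from compound 2 to compound 3 adds nothing. Among the compounds with values here, no measured compound yet carries trifluoromethyl, so the size is uncertain, and a lower number is expected, possibly not as low as that of compound 1 at 4700 nM. The expected step is an at least 8.1-fold lower number from compound 3 to compound 4 (0.91 log units; beyond the scatter). For compound 4 the estimated value is 30000 nM, with an expected range of 4000 nM to 200000 nM.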

Compound 4, half-maximal cytotoxic concentration: 4100 nM
For compound 4 the middle estimate is 7.3-fold (0.86 log units) above the measured one; the range from low to high includes it.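

In this assay, the low number at this place is not tied to the nitrile: an at least 59-fold lower number from compound 3 to compound 4 (1.77 log units; beyond the scatter), and an at least 59-fold lower number from compound 2 to compound 4 (1.77 log units; beyond the scatter). Trifluoromethyl and cyano cannot be told apart here, with a 1.1-fold lower number from compound 1 to compound 4 (0.06 log units; within the scatter), so the four compounds fall into two sets: compound 1 and compound 4 give numbers, while compound 2 and compound 3 give only limits of the assay. Both large steps therefore start from limits, not numbers, and the step between compound 2 and compound 3 cannot be read.

On these data alone, it remains open where an amine, a carboxylic acid or a longer chain at this place would fall in this assay. The compounds shown also leave open how far compound 2 and compound 3 lie from the other two, and whether this split holds with any change to the shared core.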